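The source may report more compounds than this note shows. Statements on the series, on what has been measured and on what is new or still open speak of the compounds shown alone.

Measured so far:
Compound 1, `C/C(=C\COC(=O)Nc1ccccc1)C1=CC(=O)C(C)(C)O1`: 103 ug/mL
Compound 2, `C/C(=C\C=C\c1ccccc1)C1=CC(=O)C(C)(C)O1`: 6.5 ug/mL

In a functional assay on MT4 cells (Homo sapiens) for inhibition (a higher number here means a weaker inhibitor, a lower number a stronger inhibitor), compound 1 gives 103 ug/mL, the higher of the two numbers measured. Compound 2 gives 6.5 ug/mL, a lower number, and the gap between them lies beyond the usual scatter. Compound 3, `C/C(=C\COC(=O)NCc1ccccc1)C1=CC(=O)C(C)(C)O1`, differs from compound 1 by benzyl in place of phenyl on an amide-type nitrogen. Going by the values given here, no measured pair shows this change, so its size is unknown; a step no larger than the scatter, in either direction, is expected. Compound 3 is therefore estimated at 80 ug/mL, with a range from 30 ug/mL to 250 ug/mL. That estimate means an expected step of a 1.3-fold lower number from compound 1 to compound 3 (0.11 log units; within the scatter).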

Compound 3, half-maximal inhibitory concentration: 2 ug/mL
Estimate against measurement, compound 3: 40-fold (1.60 log units) above; measured number outside the range, below it.
By their numbers in this assay, from the lowest: compound 3; then compound 2; then compound 1.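

In this assay the change from phenyl to benzyl on an amide-type nitrogen gives a 52-fold lower number from compound 1 to compound 3 (1.71 log units; beyond the scatter) and so counts as a large step. This position is therefore highly sensitive to the change, even though both groups carry one six-membered aromatic ring of carbon only. Nothing available explains why the step is so large. From the compounds shown here alone, whether a longer chain such as phenethyl in this place would lower the number further stays open. So does whether the aromatic ring is needed at all, which a cyclohexylmethyl group would test.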